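The source may hold more compounds than are shown below. What is called first, only, known or untested is meant among the compounds shown, and "the series" means these compounds.

Compounds measured in a functional assay; a lower number here means a stronger inhibitor, a higher number a weaker inhibitor:
compound 1 `CC(C)=CCOc1ccc2c(c1)OC(c1ccccc1)CC2=O`: 6070 nM
compound 2 `CC(C)=CCOc1ccc2c(c1)OC(c1ccccc1F)CC2=O`: 6360 nM
compound 3 `CC(C)=CCOc1ccc2c(c1)OC(c1ccc(F)cc1)CC2=O`: 7320 nM

The three compounds share one core and differ only in the phenyl ring that sits on the saturated ring carbon. Compound 3 stands at 7320 nM in this assay, and the steps to it read a 1.2-fold higher number from compound 1 to compound 3 (0.08 log units; within the scatter) and a 1.2-fold higher number from compound 2 to compound 3 (0.06 log units; within the scatter); both lie within the scatter, so nothing separates the three numbers. The step of a 1.0-fold higher number from compound 1 to compound 2 (0.02 log units; within the scatter) is also within the scatter.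

Compound 4 `CC(C)=CCOc1ccc2c(c1)OC(c1ccc(C)cc1)CC2=O` is the next member. It differs from compound 3 by methyl in place of fluoro on an aromatic carbon.

Going by the values given here, no measured step exchanges fluoro for methyl. The steps that come nearest are those that place fluoro in place of hydrogen on the phenyl ring, a 1.0-fold higher number from compound 1 to compound 2 (0.02 log units; within the scatter) and a 1.2-fold higher number from compound 1 to compound 3 (0.08 log units; within the scatter), and the shift of that fluoro about the ring, a 1.2-fold higher number from compound 2 to compound 3 (0.06 log units; within the scatter); each stays within the scatter. The phenyl ring has so far tolerated every change without a step beyond the scatter, so for compound 4 a step of a 1.1-fold lower number from compound 3 to compound 4 (0.05 log units; within the scatter) is expected in this assay, that is, none beyond the scatter. Compound 4 is therefore estimated at 6500 nM, with a range from 3000 nM to 14000 nM.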

Compound 4, half-maximal inhibitory concentration: 4440 nM
Compound 4: middle estimate off by 1.5-fold (0.17 log units), on the high side; the range from low to high includes it.
By their numbers in this assay, from the lowest: compounds 4, 1, 2 and 3 (each within the scatter of the next).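

Methyl is the first group on this phenyl ring that is not fluoro, and in this assay exchanging one for the other at the place para to a large group gives a 1.6-fold lower number from compound 3 to compound 4 (0.22 log units; within the scatter); that step too stays within the scatter. Set against the unsubstituted phenyl ring, the same methyl gives a 1.4-fold lower number from compound 1 to compound 4 (0.14 log units; within the scatter) and, set against the 2-fluorophenyl group, it gives a 1.4-fold lower number from compound 2 to compound 4 (0.16 log units; within the scatter), so a carbon substituent at this position separates compound 4 from none of the other three compounds, and the tolerance seen with fluoro now extends to methyl. Nothing available explains these small steps.

The four compounds leave open whether this tolerance would hold for a group with more atoms or a different character on the phenyl ring, such as a tert-butyl group, an amine or a carboxylic acid, any of which might produce a step beyond the scatter. They also leave open what a change elsewhere on the shared core would do, for instance a longer chain on the ether oxygen, as that part is identical throughout.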